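The compounds below may be only part of what the source reports. "The series", "measured", "known", "first", "only" and "open" are said of these compounds alone.

Measured so far:
- compound 1 `CNC(=O)/C=C1/COc2cc(OS(=O)(=O)c3ccc(OC)cc3)ccc21`: 0%
- compound 2 `CNC(=O)/C=C1/COc2c1ccc(OS(=O)(=O)c1cccc(Cl)c1)c2C`: 2%

In an assay (strain Sprague-Dawley) for inhibition of Amine oxidase [flavin-containing] B (Rattus norvegicus), read by spectrophotometry, with a stated time of 5 min, tested at 10 uM (on this read-out lower numbers stand for less inhibition and higher numbers for more inhibition at the one concentration tested (going by the name of the read-out)), compound 1 gives 0% and compound 2 gives 2%. Compound 2 holds the higher of the two numbers, but its gap to compound 1 is within the scatter, so neither compound is set apart from the other; both read as essentially no inhibition at the single concentration tested.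

Compound 3 `CNC(=O)/C=C1/COc2c1ccc(OS(=O)(=O)c1ccc(OC)cc1)c2C` is not yet measured. It differs from compound 2 in one place: 4-methoxyphenyl in place of 3-chlorophenyl on a sulfonyl sulfur. Going by the values given here, no step between measured compounds is available, so the expectation rests on the two values alone. Compound 1 already carries 4-methoxyphenyl on a sulfonyl sulfur and gives 0%, which offers no sign that this group raises the read-out.

The step of a number 1 percentage points lower from compound 2 to compound 3 (within the scatter) is therefore expected to be none beyond the scatter. Compound 3 is estimated at 1%, in the range 0% to 10%.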

Compound 3, a percentage reported as inhibition, at one concentration (the size of the read-out at that concentration, not a potency): 0%
For compound 3 the middle estimate is 1 percentage points above the measured one, within the range that was stated.
By their numbers in this assay, from the lowest: compounds 1, 3 and 2 (each within the scatter of the next).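

In this assay, 4-methoxyphenyl in place of 3-chlorophenyl on the sulfonyl sulfur gives a number 2 percentage points lower from compound 2 to compound 3 (within the scatter), so in this pair neither group sets its compound apart from the other. Methyl in place of hydrogen on an aromatic carbon gives no change at the digits printed from compound 1 to compound 3 (within the scatter), so this first matched comparison at that carbon likewise separates nothing while 4-methoxyphenyl stays on the sulfonyl sulfur. No measurement is at hand that bears on these flat results.

With all three compounds reading as essentially no inhibition, neither position shows here that it can influence the read-out at all. Still open, on these data alone, is whether an amine or a carboxylic acid on the aromatic ring carried by the sulfonyl sulfur, or a longer chain in place of the methyl on the aromatic carbon, would give a number beyond the scatter.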